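Dimethoxyphenyl amide in a bronchial cell inhibition series

This account rests on a few compounds, and the source may have more. Where it says the series, first, only, none or still open, it means among the compounds named here.

Compound 1, `O=C(Cn1c(=O)c(/C=C\c2ccncc2)nc2ccccc21)Nc1ccc(F)cc1`: in an ADME assay on BEAS-2B cells (Homo sapiens) for inhibition, read by MTT assay, with a stated time of 24 h (on this read-out lower numbers stand for stronger inhibition and higher numbers for weaker inhibition), compound 1 gives > 100000 nM, a limit of the assay rather than a number.
Compound 2, `O=C(Cn1c(=O)c(/C=C\c2ccncc2)nc2ccccc21)Nc1ccc(Cl)c(Cl)c1`: in this assay compound 2 gives > 100000 nM, likewise only a limit.

Within the data shown here, compound 2 therefore has no readable position among the values shown: both sit at the limit of > 100000 nM in this assay, at which 2 of the 2 values shown sit, and the single measured step, a step that the two limits leave unreadable from compound 1 to compound 2, stays unreadable between those two limits. Compound 3, `COc1ccc(NC(=O)Cn2c(=O)c(/C=C\c3ccncc3)nc3ccccc32)cc1OC`, differs from compound 2 by 3,4-dimethoxyphenyl in place of 3,4-dichlorophenyl on an amide-type nitrogen. Among the measured compounds shown here, the one measured step changes the group on the same amide-type nitrogen, yet its size cannot be read, so no step beyond the usual scatter is expected for compound 3 in this assay, which is expected to report a limit again. The estimate for compound 3 is 100000 nM, with a range from 30000 nM to 300000 nM. The expected step of a number no higher from compound 2 to compound 3 (the limit leaves the size open) is thus essentially none.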

Compound 3, half-maximal inhibitory concentration: > 100000 nM
Compound 3: only a limit was reported; the forecaster's own chance of this, stated with the estimate: 80%; the middle value lies on the limit itself.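

In this assay compound 3 gives > 100000 nM, a limit and not a number. Among these compounds, no step among compound 1, compound 2 and compound 3 can be read. How far the group on the amide-type nitrogen can shift the value stays open, because all three compounds share one limit: the limit of > 100000 nM in this assay, at which 3 of the 3 values shown sit.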